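The source may report more compounds than this note shows. Statements on the series, on what has been measured and on what is new or still open speak of the compounds shown alone.

Measured in a toxicity assay on CCRF-CEM cells (Homo sapiens) for cytotoxicity; on this read-out lower numbers stand for higher toxicity in this test and higher numbers for lower toxicity in this test:
- compound 1 `Cc1cccc2c1nc(-c1c(F)cccc1F)n2Cc1c(F)cccc1F`: > 100 uM, a limit of the assay and not a number
- compound 2 `COC(=O)c1cccc2c1nc(-c1c(F)cccc1F)n2Cc1c(F)cccc1F`: 57.7 uM
- compound 3 `Fc1cccc(F)c1Cn1c(-c2c(F)cccc2F)nc2c(Cl)cccc21`: 30.4 uM

Within the data shown here, compound 3 has one of only two true numbers in the set, and the other is its nearest neighbour, with a 1.9-fold lower number from compound 2 to compound 3 (0.28 log units; within the scatter). The remaining value is a limit.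

The next step leads to compound 4 `N#Cc1cccc2c1nc(-c1c(F)cccc1F)n2Cc1c(F)cccc1F`, with cyano in place of chloro on an aromatic carbon. Among the measured compounds shown here, no compound with cyano has been measured, so the guide is what other groups did at this same place. Two steps leave methyl: an at least 3.2-fold lower number from compound 1 to compound 3 (0.51 log units; beyond the scatter) and an at least 1.7-fold lower number from compound 1 to compound 2 (0.23 log units; that floor lies within the scatter). Both are floors, as they rest on (the limit of > 100 uM in this assay, at which 1 of the 3 values shown sits), and they give no exact size. For the measured compounds named here, the exchange of methoxycarbonyl for chloro is the only step between two true numbers, and it stayed within the scatter.

Compound 4 is therefore expected to fall near those two numbers, given the small step seen in a 1.9-fold lower number from compound 2 to compound 3 (0.28 log units; within the scatter). The estimated step, a 1.5-fold higher number from compound 3 to compound 4 (0.17 log units; within the scatter), is a slight rise that does not clearly exceed the scatter. For compound 4 the expected value is 45 uM, with an estimated range of 18 uM to 100 uM.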

Compound 4, half-maximal toxic concentration: 26.7 uM
Compound 4: the middle estimate sits 1.7-fold (0.23 log units) above what was measured, within the range that was stated.
By their numbers in this assay, from the lowest: compounds 4, 3 and 2 (each within the scatter of the next, the first and the last beyond it). At a limit, above all of these: compound 1.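

Notes on this position: in this assay, cyano and chloro on this aromatic carbon cannot be told apart, a 1.1-fold lower number from compound 3 to compound 4 (0.06 log units; within the scatter), so two quite different groups, one of a single chlorine atom and one of a carbon and a nitrogen joined by a triple bond, read alike here. New is a step between two true numbers that passes the scatter, a 2.2-fold lower number from compound 2 to compound 4 (0.33 log units; beyond the scatter), though it is only modest and the matching step from methoxycarbonyl to chloro stayed within the scatter, so the replacement of methoxycarbonyl by a smaller group has a small and only partly resolved effect on this read-out. Compound 1 with methyl remains at a limit of the assay, which makes the step to cyano, an at least 3.7-fold lower number from compound 1 to compound 4 (0.57 log units; beyond the scatter), a floor with no exact size, beyond the scatter like the floor to chloro: the limit of > 100 uM in this assay, at which 1 of the 4 values shown sits.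

On these data alone, the true number of compound 1 stays open, and with it the real size of every step away from methyl. Also open is how an amine, a carboxylic acid or a longer chain such as propyl at this place would read in this assay, since the four groups shown span only a narrow set.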